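The source may hold more compounds than are shown below. What is called first, only, known or untested is meant among the compounds shown, and "the series" means these compounds.

Measured compounds:
- compound 1 `Cc1cc(C)cc(S(=O)(=O)c2cnc3ccc(C)cc3c2N2CCC(C)CC2)c1`: in an assay on isolated protein for displacement of a labelled ligand from metabotropic glutamate receptor 5 (Homo sapiens), with a stated time of 60 min, tested at 1 uM (on this read-out lower numbers stand for less inhibition and higher numbers for more inhibition at the one concentration tested (going by the name of the read-out)), compound 1 gives 80%
- compound 2 `Cc1ccc2ncc(S(=O)(=O)c3cccc(F)c3)c(N3CCC(C)CC3)c2c1`: in this assay compound 2 gives 94%

Of the two numbers measured, compound 2 has the higher one; the step of a number 14 percentage points higher from compound 1 to compound 2 (beyond the scatter) lies beyond the scatter. That step is the only one measured, and it changed the aromatic group that sits on the sulfonyl sulfur, the same part of the molecule that is altered in compound 3 `Cc1ccc2ncc(S(=O)(=O)c3ccc(C)c(F)c3)c(N3CCC(C)CC3)c2c1`. The change from compound 2 to compound 3 is methyl in place of hydrogen on an aromatic carbon. Among the compounds with values here, the one measured step shows that the group on the sulfonyl sulfur can shift the read-out by a modest amount, and the present change is smaller than that one. For compound 3 the expected step is a number 6 percentage points lower from compound 2 to compound 3 (within the scatter), a number not beyond the scatter. The estimate for compound 3 in this assay is 88%, expected to fall between 72% and 98%.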

Compound 3, a percentage reported as inhibition, at one concentration (the size of the read-out at that concentration, not a potency): 91%
Compound 3: the middle estimate sits 3 percentage points below what was measured, within the range that was stated.
By their numbers in this assay, from the lowest: compound 1; then compounds 3 and 2 (each within the scatter of the next).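

Placed ortho to the fluoro group and para to a large group, the new methyl gives a number 3 percentage points lower from compound 2 to compound 3 (within the scatter) in this assay, so this position accepts a methyl with no change that can be told from the scatter. The 3-fluoro-4-methylphenyl group also stays clear of 3,5-dimethylphenyl on the sulfonyl sulfur, with a number 11 percentage points higher from compound 1 to compound 3 (beyond the scatter), so a single methyl on this ring does not by itself bring the number down to that of compound 1. Nothing measured here explains why either step came out as it did.

From the compounds shown here alone, what a methoxy group, an amine or a carboxylic acid would do at this same place remains open. So does what the methyl does when no fluoro group stands on the ring.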